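A few compounds are considered here, and "the series" means these few. Any claim that something is new, unique, unknown or untested is made for them only; others in the source may bear on it.

Measured compounds:
Compound 1, `Oc1ccc(-c2cc(-c3ccccc3)nc(-c3ccccc3Cl)c2)cc1`, gives 4990 nM in a functional assay on HCT-15 cells (Homo sapiens) for cytotoxicity, read by CCK-8 assay and cell counting, with a stated time of 2 days; a lower number here means a stronger inhibitor, a higher number a weaker inhibitor.
Compound 2, `Oc1ccc(-c2cc(-c3ccncc3)nc(-c3ccc(Cl)cc3)c2)cc1`, gives "not determined" (no result reported) in this assay.
Compound 3, `Oc1cccc(-c2cc(-c3ccncc3)nc(-c3ccc(Cl)cc3)c2)c1`, gives 2630 nM in this assay.

The two numbers that exist, from compound 1 and compound 3, lie within the usual scatter of one another, so neither can be called the stronger of the two. Compound 2 stands nowhere on these numbers: no value for it is known, and it shares with compound 1 and compound 3 only the same hydroxyphenyl, chlorophenyl and pyridine-bearing core built on a six-membered aromatic ring with one nitrogen.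

Compound 4, `Oc1ccc(-c2cc(-c3ccc(Cl)cc3)nc(-c3ccsc3)c2)cc1`, is the unmeasured partner of compound 2. The difference between them is thiophen-3-yl in place of pyridin-4-yl on an aromatic carbon.

Within the data shown here, no measured pair in this set changes a group at that position, so the size of the step cannot be read from the data. Among the measured compounds shown here, with nothing in the set pointing one way, the expectation is a step of no more than the scatter in this assay, in no fixed direction, and a value near the two known numbers. Compound 4 is therefore expected to give about 3500 nM, with a likely range from 1000 nM to 12000 nM.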

Compound 4, half-maximal inhibitory concentration: 6240 nM
Compound 4: the middle estimate sits 1.8-fold (0.25 log units) below what was measured; the measured number falls inside the stated range.
By their numbers in this assay, from the lowest: compounds 3, 1 and 4 (each within the scatter of the next, the first and the last beyond it).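

No step can be read from compound 4, which gives 6240 nM in this assay, since its one-place partner, compound 2, has no number to compare. The compounds shown leave open whether thiophen-3-yl in place of pyridin-4-yl changes the value at all, and in which direction. Nothing shown offers an explanation for these values.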